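Taking one methyl off compound 3

The source may hold more compounds than are shown below. What is called first, only, known or untested is meant among the compounds shown, and "the series" means these compounds.

Among the measured compounds shown here, in a functional assay on SK-MEL-5 cells (Homo sapiens) for antiproliferative activity (on this read-out higher numbers stand for weaker inhibition of growth and lower numbers for stronger inhibition of growth), compound 3 `Cc1cc(C)c2c(O)cc(-c3cccc4ccccc34)nc2n1` gives 468 nM as its reading, the higher of the two exact numbers so far. Compound 2 `Cc1cc(C)c2c(O)cc(-c3cccc(F)c3)nc2n1` gives 37.2 nM as the other, and the gap between them is well beyond the scatter. Compound 1 `Cc1ccnc2nc(-c3cccc4ccccc34)cc(O)c12` reads < 10 nM in this test, and that is a limit rather than a number.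

Compound 4 `Cc1ccc2c(O)cc(-c3cccc4ccccc34)nc2n1` is still unmeasured. It differs from compound 3 by hydrogen in place of methyl on an aromatic carbon, opposite the ring nitrogen hydrogen in place of methyl on an aromatic carbon and nothing else.

For the measured compounds named here, the one measured step of this kind is an at least 46-fold higher number from compound 1 to compound 3 (1.67 log units; beyond the scatter) and it is large, but it concerns a different methyl, since compound 1 keeps the one that leaves here. Like compound 1, compound 4 has lost one methyl of compound 3, so stronger inhibition seems likely, though probably less of a gain than the step of an at least 46-fold higher number from compound 1 to compound 3 (1.67 log units; beyond the scatter) suggests.

In this assay the expected change is a 7.8-fold lower number from compound 3 to compound 4 (0.89 log units; beyond the scatter) by estimate. Compound 4 is expected near 60 nM within an estimated range from 10 nM to 400 nM in this test.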

Compound 4, concentration for 50% growth inhibition: 13.8 nM
The estimate for compound 4 lay 4.3-fold (0.64 log units) above the measured number; low and high end bracket the measured number.
By their numbers in this assay, from the lowest: compound 4; then compound 2; then compound 3. At a limit, below all of these: compound 1.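

In this assay, the methyl opposite the ring nitrogen now has a measured effect of its own: replacing it with hydrogen gives a 34-fold lower number from compound 3 to compound 4 (1.53 log units; beyond the scatter). Until now, only the other methyl had a measured step, so this shows that compound 3 reads weaker than the compound on each side of it, whichever of its two methyls is absent. The two steps cannot be ranked by size, since an at least 46-fold higher number from compound 1 to compound 3 (1.67 log units; beyond the scatter) gives only a minimum, resting on a limit rather than a number: the limit of < 10 nM in this assay, at which 1 of the 4 values shown sits.

From the compounds shown here alone, it remains open whether only methyl is disfavoured opposite the ring nitrogen, or whether an ethyl group, a methoxy group or a chlorine atom there would also weaken growth inhibition. Nor do the compounds shown tell whether removing this methyl helps equally in compound 2, which carries a fluorine-bearing ring.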